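Sulfonamide heteroaryl variation on the shared core

A few compounds are considered here, and "the series" means these few. Any claim that something is new, unique, unknown or untested is made for them only; others in the source may bear on it.

Compound 1 `C=C1CC[C@@H]2[C@](C)(COC(C)=O)[C@H](OC(C)=O)CC[C@@]2(C)[C@H]1CC(Nc1ccc(S(=O)(=O)Nc2nccs2)cc1)C1=CCOC1=O` and compound 2 `C=C1CC[C@@H]2[C@](C)(COC(C)=O)[C@H](OC(C)=O)CC[C@@]2(C)[C@H]1CC(Nc1ccc(S(=O)(=O)Nc2ccc(Cl)nn2)cc1)C1=CCOC1=O` share one core and differ only in the heteroaryl on the sulfonamide nitrogen. In a functional assay on MDA-MB-231 cells (Homo sapiens) for inhibition, read by sulforhodamine B assay, with a stated time of 48 h (on this read-out lower numbers stand for stronger inhibition of growth and higher numbers for weaker inhibition of growth), compound 1 gives 8250 nM, while compound 2 gives 3960 nM in this assay. Among the compounds with values here, of the two numbers known so far, compound 1 stands highest, with compound 2 as its only neighbour, the step being a 2.1-fold lower number from compound 1 to compound 2 (0.32 log units; beyond the scatter). Compound 3 `C=C1CC[C@@H]2[C@](C)(COC(C)=O)[C@H](OC(C)=O)CC[C@@]2(C)[C@H]1CC(Nc1ccc(S(=O)(=O)Nc2ncccn2)cc1)C1=CCOC1=O` is not yet measured. Its difference from compound 1 is pyrimidin-2-yl in place of 1,3-thiazol-2-yl on a sulfonamide nitrogen, again on the sulfonamide nitrogen whose other neighbour is the sulfonyl sulfur. Within the data shown here, the only measured step that bears on this change is a 2.1-fold lower number from compound 1 to compound 2 (0.32 log units; beyond the scatter), where a five-membered aromatic ring with 2 hetero atoms gave way to a six-membered aromatic ring with 2 hetero atoms carrying a chlorine; pyrimidin-2-yl likewise brings a six-membered aromatic ring with 2 hetero atoms, but no chlorine. A number somewhat lower than that of compound 1 is therefore expected, and the expected step is a 1.4-fold lower number from compound 1 to compound 3 (0.14 log units; within the scatter), modest and close to the scatter. Compound 3 is estimated at 6000 nM in this assay, with a range from 2500 nM to 15000 nM.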

Compound 3, concentration for total growth inhibition: 3930 nM
Beside the measured number, compound 3's estimate is 1.5-fold (0.18 log units) above it; the range from low to high includes it.
By their numbers in this assay, from the lowest: compounds 3 and 2 (each within the scatter of the next); then compound 1.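

In this assay, pyrimidin-2-yl in place of 1,3-thiazol-2-yl on the sulfonamide nitrogen gives a 2.1-fold lower number from compound 1 to compound 3 (0.32 log units; beyond the scatter), so a second six-membered aromatic ring with 2 hetero atoms now reads lower than the five-membered ring of compound 1, though only by a modest step. Set against the chlorine-bearing ring, the same change gives a 1.0-fold lower number from compound 2 to compound 3 (0.00 log units; within the scatter), so among these three compounds the step away from compound 1 does not require a chlorine and is not tied to the 6-chloropyridazin-3-yl ring alone. Nothing available gives a reason for either step.

On these data alone, it remains open whether a plain phenyl, with no hetero atom in the ring, or a pyridin-2-yl, with a single ring nitrogen, would read with compound 2 and compound 3 or with compound 1. Also open is whether a chlorine, a methyl group or an amine on the pyrimidin-2-yl ring would move the number at all, as the only substituted ring shown here is that of compound 2.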